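Swapping hydroxy for sulfanyl on a core at the limit

The compounds below may be only part of what the source reports. "The series", "measured", "known", "first", "only" and "open" are said of these compounds alone.

Compound 2 `Cc1nc(C(C)C)n2c(O)nncc12` carries a hydroxy group on its fused core. In a functional assay for inhibition, with Homo sapiens as the target (a higher number here means a weaker inhibitor, a lower number a stronger inhibitor), compound 2 gives > 48000 nM, which is a limit of the assay rather than a measured number. Compound 1 `Cc1nc(C)n2c(S)nncc12` is a related compound that already carries a sulfanyl group. In this assay compound 1 gives > 48000 nM, again a limit and not a number. Within the data shown here, both values shown sit at the limit of > 48000 nM in this assay, at which 2 of the 2 values shown sit, so compound 2 stands at the top of what this assay can report, and no measured step between two compounds exists to lean on. Compound 3 `Cc1nc(C(C)C)n2c(S)nncc12` differs from compound 2 by sulfanyl in place of hydroxy on an aromatic carbon. Because compound 1, which holds the sulfanyl group, gives only > 48000 nM, this change offers no ground for expecting a gain. The step from compound 2 to compound 3 is expected to be a step that the limit leaves unreadable from compound 2 to compound 3, in other words none beyond the scatter. Compound 3 is estimated at 70000 nM, with a likely range from 20000 nM to 250000 nM, and most probably it too will be reported only as a limit.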

Compound 3, half-maximal inhibitory concentration: > 48000 nM
Compound 3 gave a limit, no number (the forecaster's own chance of this, stated with the estimate: 85%); the middle value lies beyond the limit too.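

Among these compounds, compound 1, compound 2 and compound 3 all stand at a limit of the assay rather than at a number, so no step among them can be read: the limit of > 48000 nM in this assay, at which 3 of the 3 values shown sit.

Going by these compounds, whether sulfanyl in place of hydroxy, or isopropyl in place of methyl, changes inhibition at all in this assay stays open, as does how these three compounds compare.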